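Swapping the amide substituent: cyclohexylamino to pyrrolidinyl

This account rests on a few compounds, and the source may have more. Where it says the series, first, only, none or still open, it means among the compounds named here.

Measured compounds:
- compound 1 `O=C(Cn1cc(CN2C(=O)C(=O)c3c(Cl)ccc(Cl)c32)nn1)NC1CCCCC1` gives 93300 nM
- compound 2 `O=C1C(=O)N(Cc2cn(CC(=O)N3CCCCC3)nn2)c2c(Cl)ccc(Cl)c21` gives 29700 nM
- compound 3 `O=C(Cn1cc(CN2C(=O)C(=O)c3c(Cl)ccc(Cl)c32)nn1)Nc1ccccc1` gives 27000 nM

All three share one core and differ only in the group carried by the carbonyl at the end of the chain. In a functional assay on SW780 cells (Homo sapiens) for inhibition, read by CCK-8 assay, with a stated time of 72 h (on this read-out lower numbers stand for stronger inhibition and higher numbers for weaker inhibition), compound 1 has the highest number of the three. Replacing its cyclohexylamino group gave a 3.1-fold lower number from compound 1 to compound 2 (0.50 log units; beyond the scatter) and a 3.5-fold lower number from compound 1 to compound 3 (0.54 log units; beyond the scatter), while between compound 2 and compound 3 the step was a 1.1-fold lower number from compound 2 to compound 3 (0.04 log units; within the scatter).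

Compound 4 `O=C1C(=O)N(Cc2cn(CC(=O)N3CCCC3)nn2)c2c(Cl)ccc(Cl)c21` has not yet been measured. It differs from compound 1 in one place: pyrrolidin-1-yl in place of cyclohexylamino on a carbonyl carbon. This change resembles the step from compound 1 to compound 2, where a ring-closed amine also took the place of the cyclohexylamino group and the number fell modestly. Compound 4 is therefore expected to follow that step, giving a 3.1-fold lower number from compound 1 to compound 4 (0.49 log units; beyond the scatter), a modest lowering. The estimate for compound 4 is 30000 nM, with a range from 10000 nM to 90000 nM.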

Compound 4, half-maximal inhibitory concentration: 48200 nM
Compound 4: middle estimate off by 1.6-fold (0.21 log units), on the low side, within the range that was stated.
By their numbers in this assay, from the lowest: compounds 3, 2, 4 and 1 (each within the scatter of the next, the first and the last beyond it).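

In this assay the pyrrolidin-1-yl group gave a 1.9-fold lower number from compound 1 to compound 4 (0.29 log units; within the scatter) and so, unlike piperidin-1-yl and anilino, does not stand clear of cyclohexylamino on this carbonyl carbon. With a 1.6-fold higher number from compound 2 to compound 4 (0.21 log units; within the scatter) and a 1.8-fold higher number from compound 3 to compound 4 (0.25 log units; within the scatter) as the other two readings, compound 4 cannot be told apart from any of the three earlier compounds, and going from the piperidin-1-yl ring to the smaller pyrrolidin-1-yl ring makes no readable difference here. Nothing at hand explains why the numbers fall where they do.

Open, from the compounds shown here alone, is how a ring with a second hetero atom, such as morpholin-4-yl, or an open-chain amine, such as dimethylamino, would behave on this carbonyl carbon. Also open, going by these compounds, is whether any group here can lower the number well beyond the values seen so far.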